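Phenyl replacing 2-hydroxyquinolin-4-yl on a fused aza core

The source may report more compounds than this note shows. Statements on the series, on what has been measured and on what is new or still open speak of the compounds shown alone.

The measured compounds are:
compound 1 `Cc1nc2c3ccccc3ccc2c2nc3c(ccc4ccccc43)c(-c3cccnc3)c12` — 3960 nM
compound 2 `Cc1nc2c3ccccc3ccc2c2nc3c(ccc4ccccc43)c(-c3ccccc3N)c12` — 12100 nM
compound 3 `Cc1nc2c3ccccc3ccc2c2nc3c(ccc4ccccc43)c(-c3cc(O)nc4ccccc34)c12` — 15800 nM

In a functional assay on AGS cells (Homo sapiens) for cytotoxicity, read by MTT assay, with a stated time of 48 h (on this read-out higher numbers stand for weaker inhibition and lower numbers for stronger inhibition), compound 3 gives 15800 nM, the highest of the three numbers. Compound 2 sits nearby, and the gap between them is a 1.3-fold higher number from compound 2 to compound 3 (0.12 log units; within the scatter). Compound 1 is further off, with a 4.0-fold higher number from compound 1 to compound 3 (0.60 log units; beyond the scatter). The three compounds share one core and differ only in the aryl group attached to it.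

Compound 4 `Cc1nc2c3ccccc3ccc2c2nc3c(ccc4ccccc43)c(-c3ccccc3)c12` is not yet measured. It differs from compound 3 in one place: phenyl in place of 2-hydroxyquinolin-4-yl on an aromatic carbon. The measured steps that bear on this change are those leading away from compound 1, whose pyridin-3-yl is the group closest to a plain phenyl: a 3.1-fold higher number from compound 1 to compound 2 (0.49 log units; beyond the scatter) and a 4.0-fold higher number from compound 1 to compound 3 (0.60 log units; beyond the scatter). Both steps raised the number when the pyridin-3-yl was exchanged for a group bearing a donor, while the step between the two donor-bearing groups, a 1.3-fold higher number from compound 2 to compound 3 (0.12 log units; within the scatter), stayed within the scatter. Going by the values given here, removing the donor and acceptors again is therefore expected to move the number back down, by a modest amount, though a group without any nitrogen has no direct precedent here. Compound 4 is thus estimated at 6000 nM in this assay, with a range of 2500 nM to 15000 nM, which corresponds to an expected step of a 2.6-fold lower number from compound 3 to compound 4 (0.42 log units; beyond the scatter).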

Compound 4, half-maximal inhibitory concentration: > 80000 nM
Compound 4 was reported as a limit; the forecaster's own chance of this, stated with the estimate: 5%; middle value at least 13-fold (1.12 log units) away from the limit.
By their numbers in this assay, from the lowest: compound 1; then compounds 2 and 3 (each within the scatter of the next). At a limit, above all of these: compound 4.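

In this assay compound 4 gives > 80000 nM, which is a limit of the assay and not a number: the limit of > 80000 nM in this assay, at which 1 of the 4 values shown sits.

Against each of the earlier compounds the plain phenyl group stands apart, with an at least 5.0-fold higher number from compound 3 to compound 4 (0.70 log units; beyond the scatter), an at least 6.6-fold higher number from compound 2 to compound 4 (0.82 log units; beyond the scatter) and an at least 20-fold higher number from compound 1 to compound 4 (1.30 log units; beyond the scatter), the last of these a large step, whereas the exchanges among pyridin-3-yl, 2-aminophenyl and 2-hydroxyquinolin-4-yl had shown only modest steps or none beyond the scatter. The position on the shared core, opposite the ring nitrogen, therefore does not accept every aromatic ring alike: among these four compounds, the only group with no hetero atom is also the only one that gives a limit, and the step from compound 2 is no more than the loss of one amino group.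

Whether nitrogen is needed here, or whether an oxygen substituent would do as well, stays open, since no phenyl ring bearing a hydroxyl or a methoxy group stands among these compounds. Nor do they show how an aminomethyl group or a pyridin-4-yl ring would behave at this place.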